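Adding 4-methylphenyl to compound 2

The source may hold more compounds than are shown below. What is called first, only, known or untested is meant among the compounds shown, and "the series" means these compounds.

- compound 1 `Cc1ccc(-c2ccc(Cl)cc2)n1-c1ccc(S(N)(=O)=O)cc1`: 6100 nM
- compound 2 `CCC(=O)c1ccn(-c2ccc(S(N)(=O)=O)cc2)c1C`: 100000 nM
- compound 3 `CCC(=O)c1cc(-c2ccc(Cl)cc2)n(-c2ccc(S(=O)(=O)NC)cc2)c1C`: 8700 nM

In a physicochemical assay for solubility, read by HPLC, in phosphate buffer, measured as kinetic solubility, at pH 7.4 (on this read-out lower numbers stand for lower solubility and higher numbers for higher solubility), compound 2 has the highest of the three numbers, and compound 1 and compound 3 both lie lower, beyond the scatter. Compound 4 `CCC(=O)c1cc(-c2ccc(C)cc2)n(-c2ccc(S(N)(=O)=O)cc2)c1C` differs from compound 2 in one place: 4-methylphenyl in place of hydrogen on an aromatic carbon, with 4-methylphenyl in place of hydrogen on an aromatic carbon, next to the ring nitrogen. Among the measured compounds shown here, no measured pair shows this change directly. A large downward step is still expected, resting on compound 3 (8700 nM) and compound 1 (6100 nM), which both carry a chlorine-bearing phenyl ring on that carbon. The estimated step is a 17-fold lower number from compound 2 to compound 4 (1.22 log units; beyond the scatter) in this assay overall. Compound 4 is estimated at 6000 nM with 2000 nM to 20000 nM as the expected range.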

Compound 4, solubility: 1000 nM
Estimate against measurement, compound 4: 6.0-fold (0.78 log units) above, outside the stated range (below it).
By their numbers in this assay, from the lowest: compound 4; then compounds 1 and 3 (each within the scatter of the next); then compound 2.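

In this assay, among the compounds shown here, the only direct reading of a change at this position is 4-methylphenyl in place of hydrogen, which gives a 100-fold lower number from compound 2 to compound 4 (2.00 log units; beyond the scatter). This single pair shows that the added group, with 0 hydrogen-bond donors and 0 hydrogen-bond acceptors, goes with a large drop on this aromatic carbon next to the ring nitrogen. Nothing measured here explains the size of this step. Still open, from the compounds shown here alone, is how the number responds when an amine or a carboxylic acid replaces the methyl on the added phenyl ring.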